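One Stereocentre Reversed in a Sulfonyl Series

The source may hold more compounds than are shown below. What is called first, only, known or untested is meant among the compounds shown, and "the series" means these compounds.

Of the compounds shown here, three with a shared core have been measured in a physicochemical assay for solubility, in phosphate buffer, with a stated time of 24 h, at pH 7.4, tested at 100 uM (on this read-out lower numbers stand for lower solubility and higher numbers for higher solubility), so far. Compound 1 (`O=C(NCc1ccc(S(=O)(=O)c2ccccc2)cc1)N1Cc2ccncc2C1`) gives 115000 nM there, compound 2 (`CN1CCC(S(=O)(=O)c2ccc(CNC(=O)N3Cc4ccncc4C3)cc2)CC1`) gives 240000 nM and compound 3 (`O=C(NCc1ccc(S(=O)(=O)N2CCC[C@@H](O)C2)cc1)N1Cc2ccncc2C1`) gives 216000 nM as its reading, within the scatter of both others. Compound 4 (`O=C(NCc1ccc(S(=O)(=O)N2CCC[C@H](O)C2)cc1)N1Cc2ccncc2C1`) departs from compound 3 only in configuration (the two compounds have the same atoms and bonds and differ only in configuration as drawn: 1 of 1 stereo elements differ; a stereocentre at a saturated ring carbon is drawn R in compound 3 and S in compound 4), with a stereocentre at a saturated ring carbon drawn R in compound 3 and S in compound 4. For the measured compounds named here, no measured pair tests such a change alone. The nearest evidence is group swaps on the sulfonyl sulfur: a 1.9-fold higher number from compound 1 to compound 3 (0.27 log units; within the scatter) and a 1.1-fold lower number from compound 2 to compound 3 (0.05 log units; within the scatter) both stay within the scatter, while a 2.1-fold higher number from compound 1 to compound 2 (0.32 log units; beyond the scatter) is modest. The step expected in this assay is none beyond the scatter, estimated as a 1.0-fold lower number from compound 3 to compound 4 (0.01 log units; within the scatter) in size. Compound 4 is expected at 210000 nM with an estimated range from 130000 nM to 320000 nM overall.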

Compound 4, solubility: 215000 nM
Beside the measured number, compound 4's estimate is 1.0-fold (0.01 log units) below it; measured number inside the range.
By their numbers in this assay, from the lowest: compounds 1, 4, 3 and 2 (each within the scatter of the next, the first and the last beyond it).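

In this assay, for the compounds shown here, reversing the stereocentre at the saturated ring carbon gives a 1.0-fold lower number from compound 3 to compound 4 (0.00 log units; within the scatter), the only reading that tests configuration alone: the fact that compounds 3 and 4 differ only in the configuration as drawn. The 3-hydroxypiperidin-1-yl group drawn S stands as the R form did against the other groups on the sulfonyl sulfur, with a 1.1-fold lower number from compound 2 to compound 4 (0.05 log units; within the scatter) and a 1.9-fold higher number from compound 1 to compound 4 (0.27 log units; within the scatter).

The compounds shown leave open whether configuration at this carbon would count equally with an amine or a carboxylic acid in place of the hydroxy group. They also leave open whether any other read-out would separate the two forms.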